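Pyrazoline series: aminophenyl replacement at the imine carbon

The compounds below may be only part of what the source reports. "The series", "measured", "known", "first", "only" and "open" are said of these compounds alone.

Measured compounds:
compound 1 `Oc1ccc(C2CC(c3ccccc3)=NN2c2ccc(Cl)cc2)cc1` — 3500 nM
compound 2 `COc1ccccc1C1=NN(c2ccc(Cl)cc2)C(c2ccc(O)cc2)C1` — "not determined" (no result reported)

In an assay on isolated protein for inhibition of protein kinase C zeta type (Homo sapiens), with a stated time of 4 min (on this read-out lower numbers stand for stronger inhibition and higher numbers for weaker inhibition), compound 1 gives 3500 nM. Compound 2 has no single number in this assay; for compound 2 the entry reads "not determined" (no result reported), so there is no anchor on which a step to the next compound could be sized.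

Compound 3 `Nc1ccc(C2=NN(c3ccc(Cl)cc3)C(c3ccc(O)cc3)C2)cc1` is the compound still to be measured. It differs from compound 2 in one place: 4-aminophenyl in place of 2-methoxyphenyl on a carbon with a double bond to nitrogen. With no value for compound 2, no direction is expected for the step from compound 2 to compound 3 in this assay, and no size beyond the scatter can be claimed.

The only measured reference in the series is compound 1 at 3500 nM. On that basis compound 3 is expected to land near 3000 nM, within a wide range from 500 nM to 20000 nM.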

Compound 3, half-maximal inhibitory concentration: 5400 nM
For compound 3 the middle estimate is 1.8-fold (0.26 log units) below the measured one; the measured number falls inside the stated range.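

In this assay the replacement of hydrogen by amino on an aromatic carbon gives a 1.5-fold higher number from compound 1 to compound 3 (0.19 log units; within the scatter), so compound 1 and compound 3 cannot be told apart. Among the compounds shown here, this is the first readable comparison at this position: the phenyl on the carbon with a double bond to nitrogen can carry an amino group with no separation from the unsubstituted compound, although this rests on a single pair. No supporting data bear on this result.

The step from compound 2 to compound 3 cannot be read, so 2-methoxyphenyl and 4-aminophenyl remain unranked at this position. Also open, going by these compounds, is whether a carboxylic acid or a dimethylamino group on this phenyl would give a value beyond the scatter from compound 1.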